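A few compounds are considered here, and "the series" means these few. Any claim that something is new, unique, unknown or untested is made for them only; others in the source may bear on it.

Working notes on the series, values from a functional assay on Jurkat cells (Homo sapiens); on this read-out lower numbers stand for stronger inhibition and higher numbers for weaker inhibition:

- compound 1 `C[C@H](NC(=O)C(=O)NCCC1CCCC1)C(=O)N[C@@H](CC(=O)O)C(=O)COc1c(F)c(F)cc(F)c1F`: 11 nM
- compound 2 `C[C@H](NC(=O)C(=O)NCc1cccc(F)c1)C(=O)N[C@@H](CC(=O)O)C(=O)COc1c(F)c(F)cc(F)c1F`: 106 nM
- compound 3 `C[C@H](NC(=O)C(=O)NCc1ccc(F)cc1)C(=O)N[C@@H](CC(=O)O)C(=O)COc1c(F)c(F)cc(F)c1F`: 197 nM

The value of compound 2 lies toward the weak end of these three numbers. Its nearest neighbour is given by a 1.9-fold higher number from compound 2 to compound 3 (0.27 log units; within the scatter), and its furthest by a 9.6-fold higher number from compound 1 to compound 2 (0.98 log units; beyond the scatter).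

The next structure is compound 4 `C[C@H](NC(=O)C(=O)NCc1cc(Cl)ccc1Cl)C(=O)N[C@@H](CC(=O)O)C(=O)COc1c(F)c(F)cc(F)c1F`, and the change is 2,5-dichlorophenyl in place of 3-fluorophenyl on a saturated chain carbon bound to an amide-type nitrogen. In words, this is 2,5-dichlorophenyl in place of 3-fluorophenyl on a saturated chain carbon bound to an amide-type nitrogen. The core is untouched.

Among the compounds with values here, no measured step covers a chlorine-bearing ring, so the evidence is indirect. Within the data shown here, the closest precedent is a 1.9-fold higher number from compound 2 to compound 3 (0.27 log units; within the scatter), the only measured exchange of one substituted phenyl for another. The larger steps, a 9.6-fold higher number from compound 1 to compound 2 (0.98 log units; beyond the scatter) and an 18-fold higher number from compound 1 to compound 3 (1.25 log units; beyond the scatter), replace cyclopentylmethyl with a fluorophenyl. They are a different kind of change and show mainly how far this position can move the number in this assay.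

The estimated step is a 1.3-fold lower number from compound 2 to compound 4 (0.12 log units; within the scatter), so no shift beyond the scatter is expected, though the uncertainty is wide. For compound 4 the expected value is 80 nM, with an estimated range from 25 nM to 250 nM.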

Compound 4, half-maximal inhibitory concentration: 4.3 nM
Estimate against measurement, compound 4: 19-fold (1.27 log units) above; measured number outside the range, below it.
By their numbers in this assay, from the lowest: compound 4; then compound 1; then compounds 2 and 3 (each within the scatter of the next).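

In this assay the position on a saturated chain carbon bound to an amide-type nitrogen can carry an aromatic ring at the low end of the series. The 2,5-dichlorophenyl group gives a 25-fold lower number from compound 2 to compound 4 (1.39 log units; beyond the scatter) and a 46-fold lower number from compound 3 to compound 4 (1.66 log units; beyond the scatter), so an exchange of one substituted phenyl for another can move the number far more than a 1.9-fold higher number from compound 2 to compound 3 (0.27 log units; within the scatter) had suggested. With a 2.6-fold lower number from compound 1 to compound 4 (0.41 log units; beyond the scatter), the cyclopentylmethyl group of compound 1 no longer marks the low end, so a phenyl ring here is not tied to the higher numbers seen for compound 2 and compound 3, and no measured information on these compounds accounts for the size of these steps.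

The compounds shown do not separate the contributions of the two chlorines of compound 4, so a phenyl ring carrying a single chlorine remains an open case. Also open, as far as these compounds go, is whether methyl or methoxy groups in place of the chlorines, or a longer chain leading to the ring, would keep the number near that of compound 4 at 4.3 nM.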